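This account rests on a few compounds, and the source may have more. Where it says the series, first, only, none or still open, it means among the compounds named here.

Working notes on the series. Compound 1 `COC1=CC(=O)c2c(c(COc3ccccc3)c(C)n2C)C1=O` and compound 3 `COC1=CC(=O)c2c(COc3ccccc3)c(C)n(C)c2C1=O` are made of the same atoms joined differently; the difference between the two cores is not broken down here. In a functional assay on MIA PaCa-2 cells (Homo sapiens) for cytotoxicity, read by MTT assay, with a stated time of 4 h (on this read-out higher numbers stand for weaker inhibition and lower numbers for stronger inhibition), compound 1 gives 1390 nM. In this assay compound 3 gives 4560 nM, the highest number among the three measured compounds. Compound 2 `COC1=CC(=O)c2c(c(COc3cccc([N+](=O)[O-])c3)c(C)n2C)C1=O` carries, on the core of compound 1, the change (nitro in place of hydrogen on an aromatic carbon). In this assay compound 2 gives 352 nM, which amounts to a 3.9-fold lower number from compound 1 to compound 2 (0.60 log units; beyond the scatter).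

Compound 4 `COC1=CC(=O)c2c(COc3cccc([N+](=O)[O-])c3)c(C)n(C)c2C1=O` is the unmeasured member. It carries, on the core of compound 3, the change (nitro in place of hydrogen on an aromatic carbon). This is the same change as the one from compound 1 to compound 2, made at the same place, and it occurs twice among the compounds shown. Going by the values given here, only one instance of it has been measured, so the expectation for compound 4 rests on a single step and on the value of compound 3.

For compound 4 a step of a 3.5-fold lower number from compound 3 to compound 4 (0.55 log units; beyond the scatter) in this assay is expected, set beside the measured step of a 3.9-fold lower number from compound 1 to compound 2 (0.60 log units; beyond the scatter), somewhat tempered because a 3.9-fold lower number from compound 1 to compound 2 (0.60 log units; beyond the scatter) is a single observation. Compound 4 is accordingly expected to give 1300 nM in this assay. For compound 4 the expected range runs from 500 nM to 3500 nM.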

Compound 4, half-maximal inhibitory concentration: 351 nM
For compound 4 the middle estimate is 3.7-fold (0.57 log units) above the measured one, and the stated range ends above it.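

In this assay the direction of the change carries from one core to the other: nitro in place of hydrogen on an aromatic carbon lowers the number on the core of compound 1 and again on the core of compound 3, here with a 13-fold lower number from compound 3 to compound 4 (1.11 log units; beyond the scatter) on the latter. The size does not carry over, so a step measured on one core gives the sign but not a reliable magnitude on the other: the same change on two cores in this assay, a 3.9-fold lower number (0.60 log units; beyond the scatter) from compound 1 to compound 2 and a 13-fold lower number (1.11 log units; beyond the scatter) from compound 3 to compound 4, 3.3-fold (0.52 log units) apart, beyond the scatter of two such steps. With the nitro group present, compound 2 gives 352 nM and compound 4 gives 351 nM, so the printed values of the two cores sit together, yet this single pair per core shows neither why the steps differ nor how the change would behave on any further core.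

From the compounds shown here alone, it remains open whether a group other than nitro in the same place, such as an amine, a nitrile or a carboxylic acid, would also give a larger step on the core of compound 3 than on the core of compound 1. Also open, going by these compounds, is whether nitro at another place on the same ring would follow these two steps, and whether the difference between the cores would persist in other cell lines.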